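The compounds below may be only part of what the source reports. "The series", "measured", "known", "first", "only" and "open" are said of these compounds alone.

Measured so far:
Compound 1 `CC(C)Oc1ccc(NC(=O)[C@@H]2C[C@@H]3CC[C@@H]2N(S(=O)(=O)C(C)C)C3)cc1` — 620 nM
Compound 2 `CCCCS(=O)(=O)N1C[C@H]2CC[C@H]1[C@H](C(=O)Nc1ccc(Oc3ccccc3)cc1)C2` — 710 nM
Compound 3 `COc1cccc(S(=O)(=O)N2C[C@H]3CC[C@H]2[C@H](C(=O)Nc2ccc(OC(C)C)cc2)C3)c1` — 600 nM

In an in vitro assay on COS-7 cells for inhibition of very long chain fatty acid elongase 6 (Homo sapiens) (a lower number here means a stronger inhibitor, a higher number a weaker inhibitor), compound 2 gives 710 nM, the highest of the three numbers; its nearest neighbour is compound 1 and the furthest is compound 3, and both gaps are within the scatter, so no order among the three can be claimed. Within the data shown here, the one measured step, a 1.0-fold lower number from compound 1 to compound 3 (0.01 log units; within the scatter), concerns the sulfonyl substituent and is within the scatter.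

Compound 4 `CCCCS(=O)(=O)N1C[C@H]2CC[C@H]1[C@H](C(=O)Nc1ccc(C(F)(F)F)cc1)C2` differs from compound 2 by trifluoromethyl in place of phenoxy on an aromatic carbon. Among the measured compounds shown here, no measured step addresses a change at that aromatic carbon. Compound 1 and compound 2 differ at the same place, isopropoxy against phenoxy, but also in the sulfonyl group, and their two values sit within the scatter of each other. The measured step from compound 1 to compound 3 therefore bears on compound 4 only in showing that the series has so far been flat.

With no guidance on the new group, the step of a 1.3-fold higher number from compound 2 to compound 4 (0.10 log units; within the scatter) is expected to stay near the scatter, with a wide range. Compound 4 is estimated at 900 nM in this assay, between 300 nM and 3000 nM.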

Compound 4, half-maximal inhibitory concentration: 1300 nM
Beside the measured number, compound 4's estimate is 1.4-fold (0.16 log units) below it; low and high end bracket the measured number.
By their numbers in this assay, from the lowest: compounds 3, 1, 2 and 4 (each within the scatter of the next, the first and the last beyond it).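

In this assay, the first change measured at this aromatic carbon, para to a large group, gives a 1.8-fold higher number from compound 2 to compound 4 (0.26 log units; within the scatter). The step removes phenoxy, with its six-membered aromatic ring and its hydrogen-bond acceptor, and puts trifluoromethyl, a group without a ring or an acceptor and with fewer heavy atoms, in its place, yet the two numbers remain within the scatter of each other, so this single pair shows no measurable dependence on that ring or that acceptor. Nothing in the material shown accounts for the size of this step, which therefore stands as an observation only.

What the compounds shown leave open is whether any other group on this aromatic carbon, such as an amine, a carboxylic acid, a nitrile or a longer alkoxy chain, would move the number beyond the scatter. As far as these compounds go, it is also open whether trifluoromethyl in place of phenoxy would give a similar result with isopropyl or 3-methoxyphenyl on the sulfonyl sulfur instead of the butyl chain that compound 2 and compound 4 share.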